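Chloro to iodo: from compound 1 to compound 3

This account rests on a few compounds, and the source may have more. Where it says the series, first, only, none or still open, it means among the compounds named here.

Among the measured compounds shown here, in a functional assay on RAW264.7 cells (Mus musculus) for inhibition, read by microscopy, with a stated time of 4 days, in the presence of a further agent that is not named here (a lower number here means a stronger inhibitor, a higher number a weaker inhibitor), compound 1 `O=C(Nc1ccc(Cl)cc1F)c1cc(Cl)ccc1O` gives 2120 nM, the lower of the two numbers so far. Compound 2 `O=C(Nc1ccc(Cl)cc1F)c1ccccc1O` gives 10000 nM. Compound 3 `O=C(Nc1ccc(I)cc1F)c1cc(Cl)ccc1O` is not yet measured. Its difference from compound 1 is iodo in place of chloro on an aromatic carbon, meta to a fluoro group and para to a large group.

For the measured compounds named here, only one measured step bears on this, and only indirectly. With hydrogen in place of chloro on an aromatic carbon, the series shows a 4.7-fold higher number from compound 1 to compound 2 (0.67 log units; beyond the scatter), a modest step beyond the scatter. That step concerns the other chloro of compound 1 and removes a halogen outright. Going by the values given here, in compound 3 the position keeps a halogen, and no measured compound carries iodo, so the direction remains open. Among the compounds with values here, a step smaller than the one to compound 2 is expected in this assay, probably none beyond the scatter.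

The expected step is a 1.1-fold lower number from compound 1 to compound 3 (0.05 log units; within the scatter). For compound 3 the estimated value is 1900 nM, with an expected range of 700 nM to 5500 nM.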

Compound 3, half-maximal inhibitory concentration: 1840 nM
Estimate against measurement, compound 3: 1.0-fold (0.01 log units) above, and the stated range covers the measured number.
By their numbers in this assay, from the lowest: compounds 3 and 1 (each within the scatter of the next); then compound 2.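

In this assay, iodo in place of chloro on the aromatic carbon meta to a fluoro group and para to a large group gives a 1.2-fold lower number from compound 1 to compound 3 (0.06 log units; within the scatter), so the two compounds cannot be told apart. Among the compounds shown here, this is the first direct reading at this position, since compounds 1 and 2 both carry chloro there and differ only at the other chloro, where the step is a 4.7-fold higher number from compound 1 to compound 2 (0.67 log units; beyond the scatter) and lies beyond the scatter; at the position now examined, one halogen can stand for the other with no change beyond the scatter. No measurement in hand bears on why the two halogens read alike.

Going by these compounds, whether this position needs a halogen at all stays open, and hydrogen, a methoxy group, an amine or a carboxylic acid at the same carbon would test that. Also open, on these data alone, is whether the loss seen on removing the other chloro recurs with iodo at this position, which a compound with hydrogen in place of that chloro and iodo kept here would show.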